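This account rests on a few compounds, and the source may have more. Where it says the series, first, only, none or still open, it means among the compounds named here.

Measured so far:
- Compound 1, `COc1ccc(C2N=C(SCc3ccccc3)NC(C)=C2C(=O)Nc2ccc(F)cc2)cc1OC`, gives 3.6%.
- Compound 2, `COc1ccc(C2N=C(SCc3ccc(Cl)cc3)NC(C)=C2C(=O)Nc2ccc(F)cc2)cc1OC`, gives 37.1%.
- Compound 3, `CC1=C(C(=O)Nc2ccc(F)cc2)C(c2ccc([N+](=O)[O-])cc2)N=C(SCc2ccccc2)N1`, gives 38.7%.

All three numbers come from a functional assay on the whole organism (artery, strain albino) with Rattus norvegicus as the target, with a stated time of 360 min, at a dose of 10 mg/kg by the oral route; a lower number here means less inhibition, a higher number more inhibition at the dose given (going by the name of the read-out). Compound 3 holds the highest of the three numbers, but its gap to compound 2 lies within the scatter, so the two cannot be told apart; only compound 1 sits clearly lower, as the step of a number 35.1 percentage points higher from compound 1 to compound 3 (beyond the scatter) shows.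

Compound 4, `CC1=C(C(=O)Nc2ccc(F)cc2)C(c2ccc([N+](=O)[O-])cc2)N=C(SCc2ccc(F)cc2)N1`, has not yet been measured. It differs from compound 3 in one place: fluoro in place of hydrogen on an aromatic carbon.

Among the measured compounds shown here, one measured step bears on this change. From compound 1 to compound 2 a chloro took the place of a hydrogen on the same aromatic carbon of the benzyl group, and the read-out rose by a number 33.5 percentage points higher from compound 1 to compound 2 (beyond the scatter). A fluoro is a different halogen entering at that spot, and compound 3 already starts from a higher number than compound 1, so the same size of rise need not repeat. The upward step is expected to be smaller, estimated at a number 9.3 percentage points higher from compound 3 to compound 4 (within the scatter), which may not clear the scatter.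

Compound 4 is therefore expected to give about 48% in this assay, within a range of 28% to 68%.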

Compound 4, a percentage reported as inhibition, in the whole organism at one dose (the size of the read-out at that dose, not a potency): 33%
The estimate for compound 4 lay 15 percentage points above the measured number, and the stated range covers the measured number.
By their numbers in this assay, from the lowest: compound 1; then compounds 4, 2 and 3 (each within the scatter of the next).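

In this assay, a fluoro at this carbon of the benzyl group gives a number 5.7 percentage points lower from compound 3 to compound 4 (within the scatter), so the 4-fluorobenzyl compound cannot be told apart from its parent, and on the 4-nitrophenyl compounds this change leaves no readable mark on the number. The earlier halogen step, a number 33.5 percentage points higher from compound 1 to compound 2 (beyond the scatter), was a chloro on the 3,4-dimethoxyphenyl compounds, so the new result shows that a halogen entering at this position does not always shift the read-out beyond the scatter. Nothing measured here accounts for the contrast between the two steps.

The halogen and the group on the saturated ring carbon both differ between these two steps, which leaves open whether the large step belongs to the chloro itself or to the 3,4-dimethoxyphenyl setting in which it was seen. Also open, from the compounds shown here alone, is how this position would respond to a bromo, a methyl or an amine on the same aromatic carbon, and whether any of them would move the number beyond the scatter on the 4-nitrophenyl compounds.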